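This account rests on a few compounds, and the source may have more. Where it says the series, first, only, none or still open, it means among the compounds named here.

Compound 1 `COCCO/C(O)=C1\C(C)=NC(C)=C(C(=O)OCCCN2C(=O)c3ccccc3S2(=O)=O)C1c1cccc([N+](=O)[O-])c1` gives 6.8 nM in a functional assay (aorta) with Oryctolagus cuniculus as the target; on this read-out higher numbers stand for weaker inhibition and lower numbers for stronger inhibition. Compound 2 `CC1=NC(C)=C(C(=O)OCCCN2C(=O)c3ccccc3S2(=O)=O)C(c2cccc([N+](=O)[O-])c2)/C1=C(\O)OCC1CCCO1` differs from it by oxolan-2-yl in place of methoxymethyl on a saturated chain carbon bound to an oxygen on an unsaturated carbon, and in this assay compound 2 gives 10.5 nM, a step of a 1.5-fold higher number from compound 1 to compound 2 (0.19 log units; within the scatter). Compound 3 `COCCO/C(O)=C1\C(C)=NC(C)=C(C(=O)OCCCN2C(=O)c3ccccc3S2(=O)=O)C1c1ccccc1Cl` differs from compound 1 in its core by 2-chlorophenyl in place of 3-nitrophenyl on a saturated ring carbon, and in this assay compound 3 gives 2.9 nM, a step of a 2.3-fold lower number from compound 1 to compound 3 (0.37 log units; beyond the scatter). Compound 4 `CC1=NC(C)=C(C(=O)OCCCN2C(=O)c3ccccc3S2(=O)=O)C(c2ccccc2Cl)/C1=C(\O)OCC1CCCO1` has not yet been measured; it differs from compound 3 by oxolan-2-yl in place of methoxymethyl on a saturated chain carbon bound to an oxygen on an unsaturated carbon, the same change as from compound 1 to compound 2, at a place described in the same words. Because a 1.5-fold higher number from compound 1 to compound 2 (0.19 log units; within the scatter) lies within the scatter, the expected step is a 1.5-fold higher number from compound 3 to compound 4 (0.18 log units; within the scatter), with the same small drift anticipated. For compound 4 in this assay the estimate is 4.4 nM, between 2.2 nM and 9 nM.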

Compound 4, half-maximal inhibitory concentration: 7.1 nM
For compound 4 the middle estimate is 1.6-fold (0.21 log units) below the measured one; the measured number falls inside the stated range.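

In this assay, oxolan-2-yl in place of methoxymethyl gives a 2.4-fold higher number from compound 3 to compound 4 (0.39 log units; beyond the scatter), and this step cannot be told apart from the one on the core of compound 1: the same change on two cores in this assay, a 1.5-fold higher number (0.19 log units; within the scatter) from compound 1 to compound 2 and a 2.4-fold higher number (0.39 log units; beyond the scatter) from compound 3 to compound 4, 1.6-fold (0.20 log units) apart, within the scatter of two such steps. 2-Chlorophenyl in place of 3-nitrophenyl gives a 1.5-fold lower number from compound 2 to compound 4 (0.17 log units; within the scatter), which likewise agrees with its earlier counterpart: the same change on two cores in this assay, a 2.3-fold lower number (0.37 log units; beyond the scatter) from compound 1 to compound 3 and a 1.5-fold lower number (0.17 log units; within the scatter) from compound 2 to compound 4, 1.6-fold (0.20 log units) apart, within the scatter of two such steps. Each change thus carried over between the two cores shown, but this single square of four compounds does not show that either change would carry over to any other core.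

The compounds shown leave open how an amine or a carboxylic acid in place of oxolan-2-yl would read. They also leave open the effect of a pyridyl group in place of 2-chlorophenyl.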